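A few compounds are considered here, and "the series" means these few. Any claim that something is new, unique, unknown or untested is made for them only; others in the source may bear on it.

Measured compounds and their values:
Compound 1 `COc1ccc(-c2cc(/C=C/C(=O)c3ccc(N)cc3)[nH]n2)cc1` gives -81% in a functional assay on SK-MEL-28 cells (Homo sapiens) for cytotoxicity, read by sulforhodamine B assay, with a stated time of 48 h, tested at 100 uM; a higher number here means a weaker effect of the compound at the concentration tested, a lower number a stronger effect.
Compound 2 `COc1ccc(C(=O)/C=C/c2cc(-c3cc(OC)c(OC)c(OC)c3)n[nH]2)cc1` gives -87% in this assay.
Compound 3 `COc1cc(-c2cc(/C=C/C(=O)c3ccc(F)c(F)c3)[nH]n2)cc(OC)c1OC` gives -39% in this assay.

In this assay compound 1 stands second highest of the three numbers. Its nearest neighbour is compound 2, whose number lies within the usual scatter of compound 1, and its furthest is compound 3, whose number lies beyond the scatter. Compound 4 `COc1ccc(-c2cc(/C=C/C(=O)c3ccc(N)cc3)[nH]n2)cc1OC` differs from compound 1 in one place: methoxy in place of hydrogen on an aromatic carbon. The only step measured among these compounds, a number 48 percentage points higher from compound 2 to compound 3 (beyond the scatter), concerns the ring on the carbonyl carbon and not the ring where compound 4 carries its added methoxy group, so it bears on the present change only as a sign of how far numbers in this assay can move. For the measured compounds named here, no measured pair shows a methoxy in place of hydrogen on that ring. For compound 4 the estimate in this assay is -80%, with a range from -95% to -55%. This means an expected step of a number 1 percentage points higher from compound 1 to compound 4 (within the scatter), not beyond the scatter.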

Compound 4, a percentage reported as activity, at one concentration (the size of the read-out at that concentration, not a potency): -93%
Compound 4: middle estimate off by 13 percentage points, on the high side; low and high end bracket the measured number.
By their numbers in this assay, from the lowest: compounds 4, 2 and 1 (each within the scatter of the next, the first and the last beyond it); then compound 3.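

In this assay, for the compounds shown here, the step of a number 12 percentage points lower from compound 1 to compound 4 (beyond the scatter) is the only measured change on the ring that carries the methoxy group, and it shows that this ring responds to substitution: a methoxy in place of hydrogen, ortho to a methoxy group, moves the number toward a stronger effect at the concentration tested. The step is modest but lies beyond the scatter, so in this one pair the position accepts the added group with no loss of effect. Nothing available explains the step.

On these data alone, whether an ethoxy group, a hydroxyl group or a fluorine atom at this place would move the number the same way stays open. So does whether the added methoxy would have the same effect with 3,4-difluorophenyl on the carbonyl carbon.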